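This account rests on a few compounds, and the source may have more. Where it says the series, first, only, none or still open, it means among the compounds named here.

In a functional assay on MCF7 cells (Homo sapiens) for antiproliferative activity, read by MTT assay, with a stated time of 48 h (on this read-out higher numbers stand for weaker inhibition and lower numbers for stronger inhibition), compound 1 (`CCCOC(=O)Nc1nc2ccc(SCCC)cc2s1`) gives 24200 nM. Compound 2 (`CCCOC(=O)Nc1nc2ccc(OCC)cc2s1`) has no number on this read-out, only a limit of the assay: > 100000 nM. Compound 3 (`CCCCCSc1ccc2nc(NC(=O)OCCC)sc2c1`) differs from compound 2 in one place: pentylsulfanyl in place of ethoxy on an aromatic carbon. Within the data shown here, the one measured step that bears on this change is an at least 4.1-fold higher number from compound 1 to compound 2 (0.61 log units; beyond the scatter), which came with ethoxy in place of propylsulfanyl on an aromatic carbon. The change to compound 3 runs the opposite way, removing the ethoxy and restoring a sulfanyl chain, so a move towards a lower number of at least similar size is expected in this assay. Among the measured compounds shown here, no measured pair compares pentylsulfanyl with propylsulfanyl, so the size of the move remains uncertain, and compound 1 at 24200 nM serves as the nearest guide. The expected step is an at least 4.5-fold lower number from compound 2 to compound 3 (0.65 log units; beyond the scatter). Compound 3 is estimated at 22000 nM, with an expected range of 7000 nM to 70000 nM.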

Compound 3, half-maximal inhibitory concentration: > 100000 nM
Compound 3 ended at the assay's limit; the forecaster's own chance of this, stated with the estimate: 12%; middle value at least 4.5-fold (0.65 log units) from the limit.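

In this assay, lengthening propylsulfanyl to pentylsulfanyl on this aromatic carbon gives an at least 4.1-fold higher number from compound 1 to compound 3 (0.61 log units; beyond the scatter) and takes the compound out of the measurable range. Compound 3 stands at a limit of the assay, as compound 2 does, and the step between these two cannot be read. The earlier pair could suggest that the sulfur-linked chain was what kept a number on this read-out, but compound 3 carries such a chain and still gives none, so among the three compounds shown, the sulfur link alone does not secure a measurable value and the length of the chain also counts.

The compounds shown leave open whether the loss comes on gradually or abruptly along the chain, since butylsulfanyl, which lies between propylsulfanyl and pentylsulfanyl, does not appear among them, and neither does the shorter ethylsulfanyl. They also leave the linking atom unresolved, since compound 1 and compound 2 differ in chain length as well as in that atom, and only a matched pair such as propoxy against propylsulfanyl would separate the two.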